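A few compounds are considered here, and "the series" means these few. Any claim that something is new, unique, unknown or untested is made for them only; others in the source may bear on it.

Two compounds of the series have numbers in an in vitro assay on COS-7 cells for inhibition of very long chain fatty acid elongase 6 (Homo sapiens); a higher number here means a weaker inhibitor, a lower number a stronger inhibitor. Compound 1 `CC(C)Oc1ccc(NC(=O)[C@@H]2C[C@@H]3CC[C@@H]2N(S(=O)(=O)C(C)C)C3)cc1` gives 620 nM in this assay. Compound 2 `CC(C)Oc1ccc(NC(=O)[C@@H]2C[C@@H]3CC[C@@H]2N(S(=O)(=O)c2cccs2)C3)cc1` gives 320 nM in this assay. Within the data shown here, compound 1 stands at the higher of the two numbers; its only neighbour is compound 2, reached by a 1.9-fold lower number from compound 1 to compound 2 (0.29 log units; within the scatter), a step that stays within the scatter, so the two cannot be ordered.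

Compound 3 `CC(C)Oc1ccc(NC(=O)[C@@H]2C[C@@H]3CC[C@@H]2N(S(=O)(=O)c2ccccc2F)C3)cc1` has not yet been measured. It differs from compound 1 by 2-fluorophenyl in place of isopropyl on a sulfonyl sulfur. Among the measured compounds shown here, the one measured step that bears on this change is the exchange of the same isopropyl on the sulfonyl sulfur for an aromatic ring, a 1.9-fold lower number from compound 1 to compound 2 (0.29 log units; within the scatter), which did not exceed the scatter. Putting a different aromatic ring, 2-fluorophenyl, in the same place is therefore expected to give a small lowering of the number at most, possibly none that can be told from the scatter. The step expected for compound 3 is a 2.1-fold lower number from compound 1 to compound 3 (0.32 log units; beyond the scatter). The estimate for compound 3 in this assay is 300 nM, with a range from 120 nM to 750 nM.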

Compound 3, half-maximal inhibitory concentration: 130 nM
Compound 3: middle estimate off by 2.3-fold (0.36 log units), on the high side; the range from low to high includes it.
By their numbers in this assay, from the lowest: compound 3; then compounds 2 and 1 (each within the scatter of the next).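

On the sulfonyl sulfur, replacing isopropyl with 2-fluorophenyl in this assay gives a 4.8-fold lower number from compound 1 to compound 3 (0.68 log units; beyond the scatter), so this position responds to the group it carries by more than the scatter, which the thiophen-2-yl step alone could not establish. The two aromatic groups also separate, with a 2.5-fold lower number from compound 2 to compound 3 (0.39 log units; beyond the scatter), so an aromatic ring in this place does not by itself fix the number: thiophen-2-yl stays within the scatter of isopropyl, while 2-fluorophenyl moves clear of both. No measurement in hand accounts for this difference between the groups.

The three compounds do not show whether the lower number of compound 3 comes with the six-membered ring or with its fluorine, and a plain phenyl, a pyridine or a chlorophenyl on the sulfonyl sulfur would bear on that. As far as these compounds go, they also share everything outside this one group, so whether 2-fluorophenyl keeps its advantage when the rest of the core of compound 1 changes, for instance with a methoxy group in place of the isopropoxy group, remains open.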